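This account rests on a few compounds, and the source may have more. Where it says the series, first, only, none or still open, it means among the compounds named here.

The numbers here come from a functional assay on RS4-11 cells (Homo sapiens) for inhibition, read by CCK-8 assay, with a stated time of 48 h; a lower number here means a stronger inhibitor, a higher number a weaker inhibitor. Of the compounds shown here, three have been measured in it. Compound 1, `COc1ccc(Oc2ccccc2-c2ccsc2S(=O)(=O)N2CCN(C(=O)Nc3ccc([N+](=O)[O-])cc3)CC2)cc1OC`, carries a urea joined to a nitrophenyl group on a piperazine; in this assay compound 1 reaches only the limit > 50000 nM, which is a boundary of the measurement rather than a number. Compound 2, `O=[N+]([O-])c1ccc(NC(=S)NCCNS(=O)(=O)c2ccc(-c3ccccc3OCc3ccccc3)s2)cc1`, has a thiourea joined to a nitrophenyl group; in this assay compound 2 gives 11300 nM. Compound 3, `COc1ccc(NC(=S)NCCNS(=O)(=O)c2sccc2-c2ccc(C)cc2Oc2ccc(O)c(O)c2)cc1`, has a thiourea joined to a methoxyphenyl group; in this assay compound 3 gives 8300 nM. Compound 3 has the lowest number among the two numbers measured, but the numbers of compound 3 and compound 2 lie within the usual scatter of each other, so they cannot be told apart.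

Compound 4, `Cc1ccc(-c2ccsc2S(=O)(=O)NCCNC(=O)Nc2cccc([N+](=O)[O-])c2)c(Oc2ccc(O)c(O)c2)c1`, has not yet been measured. It differs from compound 3 in one place: a group of 12 heavy atoms (7 carbon, 2 nitrogen, 3 oxygen; one six-membered aromatic ring of carbon only) in place of a group of 11 heavy atoms (8 carbon, 1 nitrogen, 1 oxygen, 1 sulfur; one six-membered aromatic ring of carbon only), on an amine nitrogen. Compound 2, which also has a nitrophenyl group on this side chain, gives 11300 nM, so the step is expected to be small and within the scatter, or slightly toward a weaker inhibitor. Compound 4 is expected to give 12000 nM, between 4000 nM and 40000 nM, a step of a 1.4-fold higher number from compound 3 to compound 4 (0.16 log units; within the scatter).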

Compound 4, half-maximal inhibitory concentration: 9100 nM
Beside the measured number, compound 4's estimate is 1.3-fold (0.12 log units) above it; measured number inside the range.
By their numbers in this assay, from the lowest: compounds 3, 4 and 2 (each within the scatter of the next). At a limit, above all of these: compound 1.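

Among these compounds, this is the first step in the set that changes only one place, and in this assay it reads a 1.1-fold higher number from compound 3 to compound 4 (0.04 log units; within the scatter), so compound 3 and compound 4 cannot be told apart. On this amine nitrogen, then, the (3-nitrophenyl)carbamoyl group can take the place of the sulfur-bearing group of compound 3 without a measurable difference, even though the thiourea becomes a urea and the methoxyphenyl becomes a nitrophenyl in the same step. Nothing shown here accounts for this result.

Among the compounds shown here, the single step cannot separate the two changes, which could have opposing effects that happen to cancel, and a urea with the methoxyphenyl group on this same core would help to tell them apart. On these data alone, it also remains open whether an amine or a carboxylic acid on the phenyl ring, or a longer chain to the sulfonamide, would give a step beyond the scatter.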